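The source may report more compounds than this note shows. Statements on the series, on what has been measured and on what is new or still open speak of the compounds shown alone.

Working notes on the series. Two compounds built on the shared core have numbers in a functional assay on MDA-MB-231 cells (Homo sapiens) for cytotoxicity, read by MTT assay, with a stated time of 72 h; on this read-out higher numbers stand for weaker inhibition and lower numbers for stronger inhibition. Compound 1 `CN1CCN(CCCCCn2c3c(c4ccccc42)C(=O)c2c[n+]([O-])c4ccccc4c2C3=O)CC1` gives 2270 nM in this assay, and compound 2 `CC1(C)OCC(Cn2cc(Cn3c4c(c5ccccc53)C(=O)c3c[n+]([O-])c5ccccc5c3C4=O)nn2)O1` gives 230 nM. Among these two numbers compound 1 stands highest; its nearest neighbour, compound 2, lies lower by a margin beyond the usual scatter, so the two values show that the group carried on the saturated chain from the aromatic nitrogen does move the read-out. Going by the values given here, no single-change step between measured compounds is available.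

Compound 3 `CN(C)CCCCn1c2c(c3ccccc31)C(=O)c1c[n+]([O-])c3ccccc3c1C2=O` is still to be measured in this assay. It is reached from compound 1 by one change: dimethylamino in place of (4-methylpiperazin-1-yl)methyl on a saturated chain carbon, four bonds along the chain from an aromatic nitrogen Nothing in the measured pair isolates a swap of (4-methylpiperazin-1-yl)methyl for dimethylamino, so the direction rests on the size of the change alone. The step expected is a 1.3-fold lower number from compound 1 to compound 3 (0.10 log units; within the scatter), estimated to stay within the scatter or to run slightly downward. Compound 3 is accordingly expected to give 1800 nM, with a range of 600 nM to 5000 nM.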

Compound 3, half-maximal inhibitory concentration: 350 nM
Estimate against measurement, compound 3: 5.1-fold (0.71 log units) above; measured number below the stated range.
By their numbers in this assay, from the lowest: compounds 2 and 3 (each within the scatter of the next); then compound 1.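

In this assay, going by these compounds alone, dimethylamino in place of (4-methylpiperazin-1-yl)methyl on a saturated chain carbon, four bonds along the chain from an aromatic nitrogen, gives a 6.5-fold lower number from compound 1 to compound 3 (0.81 log units; beyond the scatter), the first single-change step, which shows that the read-out responds to this change at this position. The same difference also reads as 4-(4-methylpiperazin-1-yl)butyl to 3-(dimethylamino)propyl, so the loss of the six-membered ring and the shortening of the chain come together in this one step and cannot be told apart. No measurement at hand bears on why the number moves.

Going by these compounds, it remains open whether the step follows the ring or the chain length, a question that a 4-(dimethylamino)butyl or a 3-(4-methylpiperazin-1-yl)propyl group on the same aromatic nitrogen would address. On these data alone, how a morpholine, a pyrrolidine or a primary amine would read in this place also remains open, as does whether the step would hold on a longer chain.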